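The source may report more compounds than this note shows. Statements on the series, on what has been measured and on what is new or still open speak of the compounds shown alone.

Compound 1 `O=C(Nc1ccc2nc(NC(=O)C3CCCCC3)sc2c1)c1ccccc1F` belongs to a small set built on one shared core, with the variation confined to the acyl group on the amide that sits on the benzothiazole-type portion of the molecule. In a functional assay on WI-38 VA13 cells (Homo sapiens) for cytotoxicity (on this read-out lower numbers stand for an effect already at smaller amounts and higher numbers for an effect only at larger amounts of compound), compound 1 gives 0.14 ug/mL, and on that number it stands level with compound 2 `CCCC(C)C(=O)Nc1ccc2nc(NC(=O)C3CCCCC3)sc2c1`, which gives 0.14 ug/mL; together the two carry the highest numbers of the three measured compounds. Compound 3 `Cc1[nH][n+](C)c(C)c1C(=O)Nc1ccc2nc(NC(=O)C3CCCCC3)sc2c1` gives 0.012 ug/mL, the lowest of the three, and the step of a 12-fold lower number from compound 1 to compound 3 (1.07 log units; beyond the scatter) is the only one in this set that goes beyond the scatter, while no change at the digits printed from compound 1 to compound 2 (within the scatter) and a 12-fold lower number from compound 2 to compound 3 (1.07 log units; beyond the scatter) complete the picture.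

Compound 4 `Cc1nc(C)c(C(=O)Nc2ccc3nc(NC(=O)C4CCCCC4)sc3c2)s1` is the compound not yet measured. Its change from compound 1 is 2,4-dimethyl-1,3-thiazol-5-yl in place of 2-fluorophenyl on a carbonyl carbon. The step that bears most directly on it is a 12-fold lower number from compound 1 to compound 3 (1.07 log units; beyond the scatter), where a five-membered aromatic ring with two hetero atoms also replaced the six-membered ring of carbon only on the same carbonyl carbon. The step of no change at the digits printed from compound 1 to compound 2 (within the scatter) shows that exchanging the ring for an open chain moved nothing. Because of a 12-fold lower number from compound 1 to compound 3 (1.07 log units; beyond the scatter) he expects a lower number for compound 4, though a smaller step than that, as the ring entering here carries no charge: the estimate for compound 4 is 0.05 ug/mL, between 0.015 ug/mL and 0.15 ug/mL, which corresponds to the expected step of a 2.8-fold lower number from compound 1 to compound 4 (0.45 log units; beyond the scatter).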

Compound 4, half-maximal effective concentration: 0.39 ug/mL
The estimate for compound 4 lay 7.8-fold (0.89 log units) below the measured number; measured number above the stated range.
By their numbers in this assay, from the lowest: compound 3; then compounds 1 and 2 (each within the scatter of the next); then compound 4.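

In this assay, a five-membered aromatic ring with 2 hetero atoms on this carbonyl carbon does not by itself bring the number down: with 2,4-dimethyl-1,3-thiazol-5-yl the change runs the other way, a 2.8-fold higher number from compound 1 to compound 4 (0.44 log units; beyond the scatter). Measured against the open chain the result is the same, a 2.8-fold higher number from compound 2 to compound 4 (0.44 log units; beyond the scatter), which makes this the only acyl group shown that rises beyond the scatter from the level of compound 1 and compound 2. The two five-membered rings also lie far apart, a 33-fold higher number from compound 3 to compound 4 (1.51 log units; beyond the scatter), so at this position the ring class alone does not set the number.

Nothing shown gives a reason for the direction of these steps or separates the part played by the ring from that of its two methyl groups. On these data alone, it remains open whether a 1,3-thiazol-5-yl without the two methyl groups, or a plain phenyl in place of 2-fluorophenyl, would read closer to compound 1 or to compound 4.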